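Working notes on compounds 1 to 4

The compounds below may be only part of what the source reports. "The series", "measured", "known", "first", "only" and "open" are said of these compounds alone.

Measured so far in an assay on isolated protein for activation of cGMP-dependent protein kinase 1 (Homo sapiens), read by ADP-Glo, with stated times of 30 min and 2 h, in the presence of a further agent that is not named here; a higher number here means that more compound is needed for the effect, a lower number that less compound is needed:
compound 1, `O=C(O)c1ccc2nc(CN3CCC[C@H](O[C@H](CO)c4cc(Cl)cc(Cl)c4)[C@@H]3c3ccccc3)[nH]c2c1`, gives 380 nM
compound 2, `Cc1nc(C(=O)O)ccc1CN1CCC[C@H](O[C@H](CO)c2cc(Cl)cc(Cl)c2)[C@@H]1c1ccccc1`, gives 370 nM
compound 3, `COC(=O)Nc1cc(C(=O)O)ccc1CN1CCC[C@H](O[C@H](CO)c2cc(Cl)cc(Cl)c2)[C@@H]1c1ccccc1`, gives 1000 nM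

Compound 3 carries the highest number of the three; compound 1 and compound 2 both sit at lower numbers, and both gaps to compound 3 lie beyond the scatter. Going by the values given here, the one step between measured compounds, a 1.0-fold lower number from compound 1 to compound 2 (0.01 log units; within the scatter), exchanges the group on the saturated chain carbon bound to the ring amine nitrogen, not the aromatic carbon changed here, so it bears on the present step only as a sign that the series accepts a sizeable exchange at a nearby position without movement in this assay.

Compound 4, `O=C(O)c1ccc(CN2CCC[C@H](O[C@H](CO)c3cc(Cl)cc(Cl)c3)[C@@H]2c2ccccc2)c([N+](=O)[O-])c1`, differs from compound 3 by nitro in place of (methoxycarbonyl)amino on an aromatic carbon. Among the compounds with values here, no measured pair isolates this exchange. The values of compound 1 and compound 2 show that the compound bearing (methoxycarbonyl)amino, compound 3, gives the higher number; removing that group is expected to move the number part of the way back toward them, so for compound 4 a modest drop is expected, a 1.7-fold lower number from compound 3 to compound 4 (0.22 log units; within the scatter), with a wide range. Compound 4 is therefore estimated at 600 nM, between 250 nM and 1500 nM.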

Compound 4, half-maximal effective concentration: 520 nM
Compound 4: middle estimate off by 1.2-fold (0.06 log units), on the high side; the measured number falls inside the stated range.
By their numbers in this assay, from the lowest: compounds 2, 1, 4 and 3 (each within the scatter of the next, the first and the last beyond it).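

In this assay, nitro in place of (methoxycarbonyl)amino, on an aromatic carbon ortho to a large group and meta to a carboxy group, gives a 1.9-fold lower number from compound 3 to compound 4 (0.28 log units; within the scatter) and so does not separate the two groups at this place, even though the hydrogen-bond donor of (methoxycarbonyl)amino is lost in the exchange. Compound 4 also stays within the scatter of the two compounds that carry neither group, with a 1.4-fold higher number from compound 2 to compound 4 (0.15 log units; within the scatter) and a 1.4-fold higher number from compound 1 to compound 4 (0.14 log units; within the scatter) as the steps, so the series now holds a substituted compound that cannot be told apart from compound 1 or compound 2, while compound 3 remains the only one beyond the scatter of them. Nothing available gives a reason for these numbers.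

The compounds shown leave open how a plain hydrogen, an amine or a methoxy group on this aromatic carbon would read in this assay and whether any group here matters at all. They also leave open whether the gap between compound 3 and compounds 1 and 2 follows the hydrogen-bond donor or the size of (methoxycarbonyl)amino, since nitro differs from it in both.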